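The compounds below may be only part of what the source reports. "The series", "measured", "known", "first", "only" and "open" are said of these compounds alone.

Measured so far:
- Compound 1, `O=C(Cn1cnc2cccnc21)N1CCN(c2ncsc2-c2nc3ccccc3[nH]2)CC1`: 4210 nM
- Compound 2, `C[C@H]1CN(c2scnc2-c2nc3ccccc3[nH]2)CCN1C(=O)Cn1cnc2cccnc21`: 67 nM
- Compound 3, `CCOc1ncc(-c2nc(C(F)(F)F)sc2N2CCN(C(=O)Cn3ccc4cnccc43)[C@H](C)C2)cn1`: 3.6 nM

These three compounds were tested in a functional assay on CHO-K1 cells for antagonist activity at C-X-C chemokine receptor type 3 (Homo sapiens), read by FLIPR, with a stated time of 10 min; a higher number here means a weaker inhibitor, a lower number a stronger inhibitor. Compound 3 gives the lowest number of the three and so is the strongest inhibitor here: its gap to compound 2, the nearest, lies beyond the usual scatter, and its gap to compound 1, the furthest, is larger still. Compound 2 and compound 1 share a core with each other but not with compound 3, so their values only show where compound 3 stands, not what any single change does.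

Compound 4, `CCOc1ncc(-c2nc(C(F)(F)F)sc2N2CCN(C(=O)Cn3cc(Cl)cn3)[C@H](C)C2)cn1`, has not yet been measured. It differs from compound 3 in one place: a group of 6 heavy atoms (3 carbon, 2 nitrogen, 1 chlorine; one five-membered aromatic ring with 2 hetero atoms) in place of a group of 9 heavy atoms (7 carbon, 2 nitrogen; one five-membered aromatic ring with 1 hetero atom, one six-membered aromatic ring with 1 hetero atom), on a saturated chain carbon bound to a carbonyl carbon. Going by the values given here, no pair of measured compounds shows this kind of swap, so its effect cannot be read from the data. Replacing a larger two-ring group with a smaller one-ring group is expected to move the number in this assay upward by a modest amount, toward a weaker inhibitor, though a step within the scatter would not be surprising. The estimated step of a 4.2-fold higher number from compound 3 to compound 4 (0.62 log units; beyond the scatter) reflects this. Compound 4 is therefore expected to give about 15 nM, within a range from 3 nM to 80 nM.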

Compound 4, half-maximal inhibitory concentration: 5.1 nM
For compound 4 the middle estimate is 2.9-fold (0.47 log units) above the measured one, within the range that was stated.
By their numbers in this assay, from the lowest: compounds 3 and 4 (each within the scatter of the next); then compound 2; then compound 1.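

In this assay the swap to 4-chloro-1H-pyrazol-1-yl gives a 1.4-fold higher number from compound 3 to compound 4 (0.15 log units; within the scatter) and so leaves the two compounds indistinguishable. Going by these compounds alone, this is the first direct test of this position, and it shows that, on this core, the group with one five-membered aromatic ring and 6 heavy atoms does as well as the two-ring group with 9 heavy atoms, so the second ring is not required here. No measurement available here explains why the two groups perform alike.

As far as these compounds go, what the chlorine itself contributes stays open, and a hydrogen, a methyl group or a nitrile in its place on the pyrazole would test that. Also open, from the compounds shown here alone, is how a longer chain would fare in place of the saturated chain carbon bound to a carbonyl carbon.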